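Removing One Methoxy Group: From Compound 2 to Compound 4

A few compounds are considered here, and "the series" means these few. Any claim that something is new, unique, unknown or untested is made for them only; others in the source may bear on it.

The series shares one core, seen in compound 1 `COc1ccc(-c2cc(/C=C/C(=O)c3ccc(N)cc3)[nH]n2)cc1`, compound 2 `COc1cc(-c2cc(/C=C/C(=O)c3ccc(N)cc3)[nH]n2)cc(OC)c1OC` and compound 3 `COc1cc(-c2cc(/C=C/C(=O)c3ccc(F)c(F)c3)[nH]n2)cc(OC)c1OC`. In a functional assay on T47D cells (Homo sapiens) for cytotoxicity, read by sulforhodamine B assay, with a stated time of 48 h, tested at 0.1 uM (on this read-out lower numbers stand for a stronger effect and higher numbers for a weaker effect at the one concentration tested), compound 1 gives 87%, compound 2 gives 85% and compound 3 gives 93%. Compound 2 has the lowest of the three numbers, but compound 1 and compound 3 both lie within the scatter of it. Within the data shown here, the one measured step between compounds that differ in a single place, a number 8 percentage points higher from compound 2 to compound 3 (within the scatter), concerns the group on the carbonyl carbon and stays within the scatter. Compound 4 `COc1ccc(-c2cc(/C=C/C(=O)c3ccc(N)cc3)[nH]n2)cc1OC` differs from compound 2 elsewhere: hydrogen in place of methoxy on an aromatic carbon. Among the measured compounds shown here, no measured step touches that ring in one place; compound 1 and compound 2 both carry methoxy groups on it and give numbers within the scatter of each other. With only small steps known, no step beyond the scatter is expected in this assay. Compound 4 is therefore expected to give about 86%, between 76% and 96%. The step this estimate implies, a number 1 percentage points higher from compound 2 to compound 4 (within the scatter), is expected to stay within the scatter.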

Compound 4, a percentage reported as activity, at one concentration (the size of the read-out at that concentration, not a potency): 90%
Compound 4: middle estimate off by 4 percentage points, on the low side; low and high end bracket the measured number.
By their numbers in this assay, from the lowest: compounds 2, 1, 4 and 3 (each within the scatter of the next).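

In this assay this ring carbon, ortho to a methoxy group and meta to a large group, now carries two single changes: hydrogen in place of methoxy gives a number 5 percentage points higher from compound 2 to compound 4 (within the scatter) and, in the opposite sense, methoxy in place of hydrogen gives a number 3 percentage points higher from compound 1 to compound 4 (within the scatter) at a related ring carbon. Neither change moves the number beyond the scatter, so in these compounds hydrogen and methoxy cannot be told apart at this place at the one concentration tested. Nothing available explains these small steps.

On these data alone, whether an amine or a carboxylic acid on this carbon would give a step beyond the scatter remains open. So does whether removing this methoxy group has the same small effect when 3,4-difluorophenyl replaces 4-aminophenyl on the carbonyl carbon.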